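Compound 4 in the cell tolerance assay: an expectation

The source may report more compounds than this note shows. Statements on the series, on what has been measured and on what is new or still open speak of the compounds shown alone.

The three measured compounds share one core and differ only in the chain bound to the aromatic ring nitrogen. Compound 1 `Cc1ccc2nc(N3CCCc4ccc(F)cc4C3)cc(NCC3(N)COC3)c2c1` gives a value of > 100000 nM in an ADME assay on HEp-2 cells (Homo sapiens) for cytotoxicity, read by CCK-8 assay, with a stated time of 5 days (a lower number here means that less compound is tolerated, a higher number that more compound is tolerated), which is a limit of the assay and not a number (the limit of > 100000 nM in this assay, at which 1 of the 3 values shown sits). Compound 2 `CNCCNc1cc(N2CCCc3ccc(F)cc3C2)nc2ccc(C)cc12` gives 29000 nM in this assay. Compound 3 `Cc1ccc2nc(N3CCCc4ccc(F)cc4C3)cc(NCC(C)(C)N)c2c1` gives 23000 nM in this assay, which is the lowest of the two numbers shown; the step between them is a 1.3-fold lower number from compound 2 to compound 3 (0.10 log units; within the scatter), so no order between the two can be claimed. The steps of an at least 3.4-fold lower number from compound 1 to compound 2 (0.53 log units; beyond the scatter) and an at least 4.3-fold lower number from compound 1 to compound 3 (0.63 log units; beyond the scatter) are both at least modest, but each rests on a limit.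

The unmeasured compound 4 `Cc1ccc2nc(N3CCCc4ccc(F)cc4C3)cc(NCC3CCCCN3)c2c1` differs from compound 3 by piperidin-2-yl in place of 1-amino-1-methylethyl on a saturated chain carbon bound to a nitrogen on an aromatic ring. For the measured compounds named here, the only step between two numbers here, a 1.3-fold lower number from compound 2 to compound 3 (0.10 log units; within the scatter), is within the scatter, and it exchanges one amine-bearing chain for another, as the step to compound 4 does. Going by the values given here, nothing among the measured steps points to a change beyond the scatter. Compound 4 is therefore expected to sit close to compound 3, with a step of a 1.2-fold lower number from compound 3 to compound 4 (0.06 log units; within the scatter). The estimate for compound 4 in this assay is 20000 nM, within a range from 8000 nM to 50000 nM.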

Compound 4, half-maximal cytotoxic concentration: 23000 nM
Beside the measured number, compound 4's estimate is 1.2-fold (0.06 log units) below it; the range from low to high includes it.
By their numbers in this assay, from the lowest: compounds 3, 4 and 2 (each within the scatter of the next). At a limit, above all of these: compound 1.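

In this assay, piperidin-2-yl takes the place of an open chain on this saturated chain carbon without any step beyond the scatter: no change at the digits printed from compound 3 to compound 4 (within the scatter), and a 1.3-fold lower number from compound 2 to compound 4 (0.10 log units; within the scatter). For the compounds shown here, until now, the only step between two numbers at this position had exchanged one open amine-bearing chain for another, so this result extends the picture to a group with a six-membered non-aromatic ring and more heavy atoms than 1-amino-1-methylethyl. A ring at this position does not by itself go with the limit, as 3-aminooxetan-3-yl also carries a ring and still stands apart, an at least 4.3-fold lower number from compound 1 to compound 4 (0.63 log units; beyond the scatter), a step that rests on a limit of the assay: the limit of > 100000 nM in this assay, at which 1 of the 4 values shown sits.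

The compounds shown leave open whether the oxygen of the 3-aminooxetan-3-yl group goes with this separation, which a comparison with an azetidine or cyclobutylamine ring could address. They also leave open whether a chain ending in a hydroxyl group or a carboxylic acid, with no amine on it, would stay within the scatter of compound 2, compound 3 and compound 4 in this assay.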